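The source may report more compounds than this note shows. Statements on the series, on what has been measured and on what is new or still open speak of the compounds shown alone.

Series notes: sulfonamide-bearing bicyclic core with a pyrazole carrying a trifluoromethyl group and a variable aryl substituent.

Compound 1 `NS(=O)(=O)c1ccc2nc(-n3nc(C(F)(F)F)cc3-c3ccc(Br)cc3)sc2c1` gives 43% in a functional assay on the whole organism (strain Wistar albino) for inhibition, with Rattus norvegicus as the target, read by paw edema, with stated times of 30 min and 4 h, at a dose of 50 mg/kg by the oral route; a higher number here means more inhibition at the dose given (going by the name of the read-out), a lower number less inhibition. Compound 2 `NS(=O)(=O)c1ccc2nc(-n3nc(C(F)(F)F)cc3-c3ccco3)sc2c1` gives 54% in this assay, the highest of the two numbers measured, with compound 1 the nearest and lower. Among the compounds with values here, the one step measured so far, a number 11 percentage points higher from compound 1 to compound 2 (beyond the scatter), arises from the exchange of the aryl group on an aromatic carbon of the pyrazole.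

Compound 3 `NS(=O)(=O)c1ccc2nc(-n3nc(C(F)(F)F)cc3-c3ccc4ccccc4c3)sc2c1` is not yet measured. It differs from compound 2 at the same aryl position: naphthalen-2-yl in place of furan-2-yl on an aromatic carbon. The measured step from compound 1 to compound 2 bears on this only indirectly: it shows that swapping one carbon-only six-membered aromatic ring for the five-membered ring with one hetero atom gave a modest gain. Compound 3 returns to a carbon-only aromatic system, now with two fused six-membered rings, so a modest loss relative to compound 2 is expected, while a result within the scatter of compound 2 cannot be excluded. In this assay compound 3 is estimated at 45%, range 30% to 60%, meaning an expected step of a number 9 percentage points lower from compound 2 to compound 3 (within the scatter).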

Compound 3, a percentage reported as inhibition, in the whole organism at one dose (the size of the read-out at that dose, not a potency): 20%
Estimate against measurement, compound 3: 25 percentage points above; the measured number lies below the stated range.
By their numbers in this assay, from the lowest: compound 3; then compound 1; then compound 2.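

In this assay, within the data shown here, the aryl position on the aromatic carbon of the five-membered ring proves much more sensitive than the earlier compounds could show, with naphthalen-2-yl in place of furan-2-yl giving a number 34 percentage points lower from compound 2 to compound 3 (beyond the scatter) and naphthalen-2-yl in place of 4-bromophenyl giving a number 23 percentage points lower from compound 1 to compound 3 (beyond the scatter). Both steps lie beyond the scatter, so compound 3 has the lowest number of the three, and the two groups made of carbon-only six-membered aromatic rings do not behave as one class: the absence of a ring hetero atom does not by itself set the number here. Nothing available explains why the number falls with naphthalen-2-yl, as no supporting measurement bears on this change.

Going by these compounds, with only furan-2-yl, 4-bromophenyl and naphthalen-2-yl at this position, it remains open whether the higher number of compound 2 belongs to furan-2-yl specifically or would extend to a group such as thiophen-2-yl, pyridin-3-yl or unsubstituted phenyl. On these data alone, it is also open how this position would respond to a non-aromatic group such as morpholine or a carboxylic acid, and each compound here is read at a single dose.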